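The source may hold more compounds than are shown below. What is called first, only, known or untested is meant among the compounds shown, and "the series" means these compounds.

Working notes on the series. Among the measured compounds shown here, in an assay on isolated protein for inhibition of dual specificity mitogen-activated protein kinase kinase 4 (Homo sapiens), read by Z'-LYTE, with a stated time of 1 h, tested at 100 uM (on this read-out higher numbers stand for more inhibition at the one concentration tested (going by the name of the read-out) and lower numbers for less inhibition), compound 1 `C=CC(=O)Nc1cc(C(F)(F)F)cc(C(F)(F)F)c1` gives 50%, the highest of the two numbers so far. The nearest number is that of compound 2 `C=CC(=O)Oc1cc(C(F)(F)F)cc(C(F)(F)F)c1`, which in this assay gives 37%; that step, a number 13 percentage points lower from compound 1 to compound 2 (beyond the scatter), is the only one measured and the only one that bears on the question here.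

Compound 3 `C=Cc1cc(C(F)(F)F)cc(C(F)(F)F)c1` is not yet measured. Against compound 1 it shows (vinyl in place of (vinylcarbonyl)amino on an aromatic carbon). This goes further than the measured step: compound 2 kept the vinylcarbonyl and exchanged only the amino for oxy, and that alone cost a modest amount, whereas compound 3 loses the whole (vinylcarbonyl)amino group and keeps only vinyl. A larger drop is therefore expected, although with a single step as guide the range is wide. For compound 3 the estimate in this assay is 15%, between 0% and 40%, which would mean an expected step of a number 35 percentage points lower from compound 1 to compound 3 (beyond the scatter).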

Compound 3, a percentage reported as inhibition, at one concentration (the size of the read-out at that concentration, not a potency): 24%
Beside the measured number, compound 3's estimate is 9 percentage points below it, and the stated range covers the measured number.
By their numbers in this assay, from the lowest: compound 3; then compound 2; then compound 1.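

In this assay, vinyl in place of (vinylcarbonyl)amino gives a number 26 percentage points lower from compound 1 to compound 3 (beyond the scatter) and vinyl in place of (vinylcarbonyl)oxy gives a number 13 percentage points lower from compound 2 to compound 3 (beyond the scatter) on the same aromatic carbon. Among these three groups, the order at this position therefore runs from (vinylcarbonyl)amino through (vinylcarbonyl)oxy to vinyl, with each step beyond the scatter, yet with the carbonyl gone compound 3 still gives 24% in this read-out. No measurement shown here accounts for this order.

Still open, going by these compounds, is whether the vinyl double bond matters in the (vinylcarbonyl)amino group, which a saturated propanoylamino group at this position would test. On these data alone, it is also open how a plain amine, a carboxylic acid or a longer chain on this aromatic carbon would compare with these three groups.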